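A few compounds are considered here, and "the series" means these few. Any claim that something is new, unique, unknown or untested is made for them only; others in the source may bear on it.

Working notes on the series, all read in a functional assay on T47D cells (Homo sapiens) for inhibition, read by CCK-8 assay, with a stated time of 72 h, tested at 1 uM; on this read-out higher numbers stand for more inhibition of growth at the one concentration tested and lower numbers for less inhibition of growth. Compound 1 `CN(C)C(=O)c1cc2cnc(Nc3ccc(N)cn3)nc2n1C1CCCC1` gives 18.8%, compound 2 `CN(C)C(=O)c1cc2cnc(Nc3ccc(NC(=O)C4(C(=O)Nc5ccc(Cl)cc5)CC4)cc3)nc2n1C1CCCC1` gives 22.8%, and compound 3 `CN(C)C(=O)c1cc2cnc(Nc3ccc(NC(=O)C4(C(=O)Nc5cccc(F)c5)CC4)cc3)nc2n1C1CCCC1` gives -3.2%. Compound 3 is the lowest of the three numbers, and its gaps to both others lie beyond the scatter.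

Compound 4 `CN(C)C(=O)c1cc2cnc(Nc3ccc(NC(=O)C4(C(=O)Nc5ccccc5F)CC4)cc3)nc2n1C1CCCC1` is still unmeasured. Its difference from compound 3 is 2-fluorophenyl in place of 3-fluorophenyl on an amide-type nitrogen. The two have the same atoms, joined differently: 2-fluorophenyl in place of 3-fluorophenyl on an amide-type nitrogen.

Among the compounds with values here, one measured step bears on this place: a number 26 percentage points lower from compound 2 to compound 3 (beyond the scatter). That step shows that the read-out can move when the group on this nitrogen changes, but it also exchanges chlorine for fluorine. Within the data shown here, no measured pair compares two fluorophenyl groups, so its size transfers only loosely. Among the measured compounds shown here, compound 3 stands at -3.2%, the bottom of the series so far, so a small rise is expected rather than a further fall, probably not clearly beyond the scatter.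

The expected change is a number 8.2 percentage points higher from compound 3 to compound 4 (within the scatter). For compound 4 the estimated value is 5%, with an expected range from -10% to 22%.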

Compound 4, percent growth inhibition at one concentration: 85.2%
Beside the measured number, compound 4's estimate is 80.2 percentage points below it; the measured number lies above the stated range.
By their numbers in this assay, from the lowest: compound 3; then compounds 1 and 2 (each within the scatter of the next); then compound 4.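

In this assay, 2-fluorophenyl in place of 3-fluorophenyl on an amide-type nitrogen gives a number 88.4 percentage points higher from compound 3 to compound 4 (beyond the scatter) with the same atoms joined differently, so the read-out at this place depends on how the fluorophenyl group is joined and not only on which atoms it carries. Against 4-chlorophenyl at the same nitrogen, 2-fluorophenyl gives a number 62.4 percentage points higher from compound 2 to compound 4 (beyond the scatter) and the earlier downward step gains a counterpart, showing that a change at this place can raise the growth inhibition far beyond the level of compound 2 as well as lower it. Nothing in hand accounts for the size of either step.

The compounds shown do not tell whether the high number belongs to fluorine in particular or extends to other 2-substituted groups such as 2-chlorophenyl or 2-methoxyphenyl, nor how 4-fluorophenyl or unsubstituted phenyl would stand in this comparison. Going by these compounds, the read-out also comes from a single concentration on one cell line, so the standing of compound 4 across a range of concentrations and in other cells remains open.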